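A few compounds are considered here, and "the series" means these few. Any claim that something is new, unique, unknown or untested is made for them only; others in the source may bear on it.

Compound 1 `Cc1cc(O)c(C2=NN(c3ccc(S(N)(=O)=O)cc3)C(c3ccccc3O)C2)cc1Cl` is one of two close relatives tested in a functional assay on NCI/ADR-RES cells (Homo sapiens) for antiproliferative activity, with a stated time of 48 h (a lower number here means a stronger inhibitor of growth, a higher number a weaker inhibitor of growth), where compound 1 gives 3610 nM. Among the measured compounds shown here, its companion, compound 2 `Cc1cc(O)c(C2=NN(c3ccc(S(N)(=O)=O)cc3)C(c3ccccc3Cl)C2)cc1Cl`, gives 2700 nM in this assay, and the only change between the two is a chloro in place of hydroxy on an aromatic carbon; the step from compound 1 to compound 2 is a 1.3-fold lower number from compound 1 to compound 2 (0.13 log units; within the scatter). So compound 1 has the highest of the two numbers, with nothing beyond the scatter separating them. Compound 3 `COc1ccc(C2CC(c3cc(Cl)c(C)cc3O)=NN2c2ccc(S(N)(=O)=O)cc2)c(OC)c1OC` has not yet been measured. It differs from compound 1 at the same saturated ring carbon, but more broadly: 2,3,4-trimethoxyphenyl in place of 2-hydroxyphenyl on a saturated ring carbon. For the measured compounds named here, the one measured step at this place was small, which speaks for a position that tolerates change, though no measured pair mirrors the swap to a trimethoxyphenyl. Compound 3 is therefore expected to sit near compound 1, with a step of a 1.4-fold lower number from compound 1 to compound 3 (0.16 log units; within the scatter), giving an estimate of 2500 nM with a range from 800 nM to 8000 nM.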

Compound 3, concentration for 50% growth inhibition: 2580 nM
The estimate for compound 3 lay 1.0-fold (0.01 log units) below the measured number; low and high end bracket the measured number.
By their numbers in this assay, from the lowest: compounds 3, 2 and 1 (each within the scatter of the next).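

In this assay, 2,3,4-trimethoxyphenyl, with 12 heavy atoms and 3 hydrogen-bond acceptors, stands on the saturated ring carbon where 2-hydroxyphenyl has 7 heavy atoms and 1 acceptor, yet the result is a 1.4-fold lower number from compound 1 to compound 3 (0.15 log units; within the scatter). Against the chloro-bearing ring the result is a 1.0-fold lower number from compound 2 to compound 3 (0.02 log units; within the scatter), so this position now accepts a far bulkier aryl group, not only the single-atom swap seen before, with no step beyond the scatter. Nothing measured here explains why these numbers stay so close.

On these data alone, all three compounds carry a substituted phenyl ring at this carbon, so it remains open whether an amine, a carboxylic acid or a longer alkyl chain would fit there equally well. Also open, as far as these compounds go, is whether the 4-sulfamoylphenyl group tolerates change in the same way.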